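A few compounds are considered here, and "the series" means these few. Any claim that something is new, unique, unknown or untested is made for them only; others in the source may bear on it.

Measured so far, in a physicochemical assay for lipophilicity, read by HPLC, at pH 7.5; a higher number here means a more lipophilic compound, a lower number a more polar compound:
compound 1 `CC[C@@H](Nc1c(C#N)c(-c2ccc(-c3cccc(Cl)c3OC)cc2)nc2cnccc12)C(N)=O`: 3.1
compound 2 `CCCCC(Nc1c(C#N)c(-c2ccc(-c3ccccc3OCC)cc2)nc2cnccc12)C(N)=O`: 3.6
compound 3 `CC[C@@H](Nc1c(C#N)c(-c2ccc(-c3cccc(Cl)c3F)cc2)nc2cnccc12)C(=O)O`: 2.2

Among these three numbers compound 1 stands second highest. Compound 2 lies above it, by a gap that is beyond the usual scatter of this assay, and compound 3 lies furthest from it, below, again by a gap beyond the scatter. No two of these three compounds differ in only one place, so none of the gaps between them can be tied to a single structural change.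

The unmeasured compound 4 `CC[C@@H](Nc1c(C#N)c(-c2ccc(-c3cccc(OC)c3)cc2)nc2cnccc12)C(N)=O` does differ from compound 1 in a single place: 3-methoxyphenyl in place of 3-chloro-2-methoxyphenyl on an aromatic carbon. The group that leaves carries a chlorine and an oxygen; the group that enters keeps the oxygen and drops the chlorine, so compound 4 is one heavy atom smaller than compound 1.

Without a measured pair of this kind, the expectation has to rest on the count of what leaves and what enters. Losing a chlorine from an aromatic ring is expected to lower the number in this assay by a moderate step, clearly beyond the scatter. For compound 4 the step from compound 1 to compound 4 is therefore expected to be a number 0.60 log units lower from compound 1 to compound 4 (beyond the scatter). Compound 4 is estimated at 2.5, with a range from 2.1 to 2.9.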

Compound 4, distribution coefficient: 2.7
Compound 4: middle estimate off by 0.20 log units, on the low side; measured number inside the range.
By their numbers in this assay, from the lowest: compound 3; then compound 4; then compound 1; then compound 2.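

In this assay, going by these compounds alone, the earlier compounds offered no gap that could be tied to one structural change, whereas this pair gives a first step at a single place, on an aromatic carbon para to a large group: a number 0.40 log units lower from compound 1 to compound 4 (beyond the scatter). The step is not simply the removal of a chlorine, since the names 3-chloro-2-methoxyphenyl and 3-methoxyphenyl show that the methoxy group carries a different number in each, so the loss of the chlorine and the move of the methoxy group arrive together and this single step cannot divide the change between them. No measurement shown here explains the step, so its cause remains unassigned.

The compounds shown leave open how much of the step belongs to each part, which a 3-chlorophenyl or a 2-methoxyphenyl at the same place would help to separate. They also leave open how this place responds to a group of another kind, such as a 3-aminophenyl, and whether the step would keep its size on a different side chain of the shared core.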